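The source may hold more compounds than are shown below. What is called first, only, known or untested is meant among the compounds shown, and "the series" means these compounds.

Among the compounds with values here, compound 2 `Cc1ccc(CS/C(=C/c2c(O)cc(O)cc2O)C(=O)c2ccc(Cl)cc2)cc1` gives 50000 nM in a functional assay on DU-145 cells (Homo sapiens) for inhibition, read by trypan blue exclusion, with a stated time of 96 h (on this read-out lower numbers stand for stronger inhibition of growth and higher numbers for weaker inhibition of growth), the higher of the two numbers measured so far; the nearest is compound 1 `O=C(/C(=C\c1c(O)cc(O)cc1O)SCc1ccc(Cl)cc1Cl)c1ccc(Cl)cc1`, which gives 25000 nM in this assay. Within the data shown here, the one measured step bearing on the benzyl ring is a 2.0-fold higher number from compound 1 to compound 2 (0.30 log units; within the scatter), a change that stays within the scatter. Compound 3 `O=C(/C(=C\c1c(O)cc(O)cc1O)SCc1ccc(Cl)cc1)c1ccc(Cl)cc1` differs from compound 2 by chloro in place of methyl on an aromatic carbon. Since the related swap on that ring moved little, compound 3 is expected to sit close to compound 2, with a 1.4-fold lower number from compound 2 to compound 3 (0.15 log units; within the scatter) anticipated to lie within the scatter. Compound 3 is therefore estimated at 35000 nM, between 15000 nM and 80000 nM.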

Compound 3, concentration for 50% growth inhibition: > 100000 nM
Compound 3: a limit, no number; the forecaster's own chance of this, stated with the estimate: 10%; middle value at least 2.8-fold (0.45 log units) from the limit.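

In this assay compound 3 carries a limit and not a number: the limit of > 100000 nM in this assay, at which 1 of the 3 values shown sits. As far as these compounds go, replacing 4-methylbenzyl with 4-chlorobenzyl gives an at least 2.0-fold higher number from compound 2 to compound 3 (0.30 log units; that floor lies within the scatter), so this change has only a floor and its true size stays unknown. Hydrogen in place of chloro on an aromatic carbon gives an at least 4.0-fold higher number from compound 1 to compound 3 (0.60 log units; beyond the scatter), the first step on this ring shown to exceed the scatter, so the 2,4-dichlorobenzyl and 4-chlorobenzyl groups are not interchangeable here. The compounds shown leave open how a methoxy group or an amine on this ring would read. They also leave open how a longer chain in place of the benzyl group would read.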